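A few compounds are considered here, and "the series" means these few. Any claim that something is new, unique, unknown or untested is made for them only; others in the source may bear on it.

Compound 1 `O=c1c2ccccc2c(-c2cccnc2)nn1CC1CCCCC1` and compound 2 `CC(=O)OCCn1nc(-c2cccnc2)c2ccccc2c1=O` share one core and differ in what hangs from the aromatic nitrogen. In an assay on isolated protein (Oryctolagus cuniculus) with Thromboxane-A synthase (Homo sapiens) as the target, tested at 1 uM (on this read-out lower numbers stand for less inhibition and higher numbers for more inhibition at the one concentration tested (going by the name of the read-out)), compound 1 gives 98%, while compound 2 gives 32%, the lower of the two numbers shown; the single step of a number 66 percentage points lower from compound 1 to compound 2 (beyond the scatter) is the only one at hand. Compound 3 `CCOC(=O)CCCn1nc(-c2cccnc2)c2ccccc2c1=O` differs from compound 2 by (ethoxycarbonyl)methyl in place of acetoxy on a saturated chain carbon, two bonds along the chain from an aromatic nitrogen. That earlier step touched the same chain but exchanged different groups, so it bears only loosely here, and a modest rise is expected, a number 18 percentage points higher from compound 2 to compound 3 (beyond the scatter). Compound 3 is therefore estimated at 50%, within 20% to 80%.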

Compound 3, a percentage reported as inhibition, at one concentration (the size of the read-out at that concentration, not a potency): 95%
Compound 3: the middle estimate sits 45 percentage points below what was measured, and the stated range ends below it.
By their numbers in this assay, from the lowest: compound 2; then compounds 3 and 1 (each within the scatter of the next).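

In this assay, the change at this position gives a number 63 percentage points higher from compound 2 to compound 3 (beyond the scatter), although acetoxy and (ethoxycarbonyl)methyl carry the same hydrogen-bond counts and differ in heavy atoms. A match in those counts therefore does not keep the read-out steady here. The cyclohexyl group is also not the only substituent compatible with a high number, as 2-(ethoxycarbonyl)ethyl in its place gives a number 3 percentage points lower from compound 1 to compound 3 (within the scatter). Nothing available explains the large step between the two chains. As far as these compounds go, it remains open how a carboxylic acid or an amine at the end of the chain, or a longer chain, would read.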